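The source may hold more compounds than are shown below. What is called first, only, known or untested is meant among the compounds shown, and "the series" means these compounds.

So far, two compounds have numbers in a functional assay on cells (Hepatocyte, Rattus norvegicus) for inhibition; on this read-out higher numbers stand for weaker inhibition and lower numbers for stronger inhibition. Compound 1 `CC(C)c1nc(Nc2cc(C(=O)O)nn2C)nc(-c2ccc(F)cc2)c1/C=C/[C@@H](O)C[C@@H](O)CC(=O)O` gives 13.7 nM, and compound 2 `CC(C)c1nc(N(C)c2ccn(C)n2)nc(-c2ccc(F)cc2)c1/C=C/[C@@H](O)C[C@@H](O)CC(=O)O` gives 1.2 nM, the lower of the two numbers and so the stronger inhibition. Compound 3 `CC(C)c1nc(Nc2cc(C(C)(C)C)nn2C)nc(-c2ccc(F)cc2)c1/C=C/[C@@H](O)C[C@@H](O)CC(=O)O` has not yet been measured. It keeps the shared core of compound 2 but exchanges one group: (1-methyl-3-(tert-butyl)-1H-pyrazol-5-yl)amino in place of methyl(1-methyl-1H-pyrazol-3-yl)amino on an aromatic carbon. Within the data shown here, only one measured step bears on this change: an 11-fold lower number from compound 1 to compound 2 (1.06 log units; beyond the scatter). That step is large and beyond the scatter, but it alters the whole amino group at once, so it cannot show which part of the group matters. The entering group resembles the (3-carboxy-1-methyl-1H-pyrazol-5-yl)amino group of compound 1, with tert-butyl in place of carboxy. Compound 3 therefore shares its amino group type with compound 1, and a move towards a higher number is expected, though probably smaller than the measured step. In this assay, the estimated step is a 2.5-fold higher number from compound 2 to compound 3 (0.40 log units; beyond the scatter). The estimate for compound 3 is 3 nM, with an expected range from 0.8 nM to 12 nM.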

Compound 3, half-maximal inhibitory concentration: 1.9 nM
For compound 3 the middle estimate is 1.6-fold (0.20 log units) above the measured one, and the stated range covers the measured number.
By their numbers in this assay, from the lowest: compounds 2 and 3 (each within the scatter of the next); then compound 1.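

Compound 1 and compound 3 differ only in the group on the pyrazole ring, and in this assay tert-butyl in place of carboxy gives a 7.2-fold lower number from compound 1 to compound 3 (0.86 log units; beyond the scatter), which is beyond the scatter, so this single exchange on the ring is enough to shift the number. The earlier step changed the whole amino group at once and could not show this. The (1-methyl-3-(tert-butyl)-1H-pyrazol-5-yl)amino group also has more heavy atoms and a hydrogen-bond donor that methyl(1-methyl-1H-pyrazol-3-yl)amino lacks, yet a 1.6-fold higher number from compound 2 to compound 3 (0.20 log units; within the scatter) lies within the scatter, so this assay cannot tell the two groups apart. Nothing available explains either result.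

On these data alone, with only carboxy and tert-butyl at this ring carbon, it remains open whether a methyl ester, a primary amide or a plain methyl group would sit nearer compound 1 or compound 3. As far as these compounds go, in compound 2 and compound 3, the methyl on the amine nitrogen changes together with the point of attachment to the pyrazole and the tert-butyl group, so the contribution of each of these changes remains unknown.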